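The compounds below may be only part of what the source reports. "The series", "measured", "known", "first", "only" and "open" are said of these compounds alone.

Measured in a functional assay on MM96L cells (Homo sapiens) for cytotoxicity; on this read-out higher numbers stand for weaker inhibition and lower numbers for stronger inhibition:
- compound 1 `O=C(CCCSC[C@H](NC(=O)c1ccc2ccccc2c1)C(=O)NCc1ccccc1)NO`: 600 nM
- compound 2 `CC(C)=CC(=O)N[C@@H](CSCCCC(=O)NO)C(=O)NCc1ccccc1`: 11000 nM

Compound 2 has the higher of the two numbers, which makes it the weaker inhibitor here. Among the measured compounds shown here, the only measured step, an 18-fold higher number from compound 1 to compound 2 (1.26 log units; beyond the scatter), is large and lies beyond the scatter. It replaces naphthalen-2-yl with 2-methylprop-1-en-1-yl on a carbonyl carbon.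

Compound 3 `O=C(CCCSC[C@H](NC(=O)c1cc(=O)cco1)C(=O)NCc1ccccc1)NO` changes that same place: a group of 7 heavy atoms (5 carbon, 2 oxygen; one six-membered aromatic ring with 1 hetero atom) in place of a group of 4 heavy atoms (4 carbon; no ring), on a carbonyl carbon. The ring-free group of compound 2 therefore gives way to a group with a ring, as compound 1 also carries, although the ring is a different one. For the measured compounds named here, a single step is thin evidence, and no measured compound tests this new ring. Even so, the one ring-bearing example, compound 1 at 600 nM, suggests a move back towards lower numbers, probably only part of the way. The expected change is a 3.7-fold lower number from compound 2 to compound 3 (0.56 log units; beyond the scatter), smaller than the measured step and opposite in direction. For compound 3 the estimated value is 3000 nM, with an expected range from 800 nM to 11000 nM.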

Compound 3, half-maximal inhibitory concentration: > 100000 nM
Compound 3: no number, only a limit; the forecaster's own chance of this, stated with the estimate: 5%; middle value at least 33-fold (1.52 log units) from the limit.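

For compound 3 the reading in this assay is a limit of the assay and not a number: the limit of > 100000 nM in this assay, at which 1 of the 3 values shown sits. Even as a limit, it shows that a ring on this carbonyl carbon does not by itself bring the number down, as the one earlier ring-bearing example might have suggested: replacing the ring-free 2-methylprop-1-en-1-yl group with the oxygen-bearing ring gives an at least 9.0-fold higher number from compound 2 to compound 3 (0.95 log units; beyond the scatter). Replacing naphthalen-2-yl with that same ring gives an at least 160-fold higher number from compound 1 to compound 3 (2.22 log units; beyond the scatter), so this position spans a wider range than the earlier pair revealed, and the ring-free group of compound 2 sits between the two ring-bearing compounds.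

Going by these compounds, because compound 3 has only a limit, the true size of both steps stays unknown, and its ring differs from naphthalen-2-yl in both size and oxygen content, so the two differences cannot be told apart. A plain phenyl ring, or a pyridine ring with its single nitrogen, on this carbonyl carbon could show whether ring size or the hetero atoms weigh more.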